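From nitro to methylcarbamoyl on the shared core

A few compounds are considered here, and "the series" means these few. Any claim that something is new, unique, unknown or untested is made for them only; others in the source may bear on it.

Measured in a physicochemical assay for solubility, with a stated time of 4 h, at pH 7.4; on this read-out lower numbers stand for lower solubility and higher numbers for higher solubility:
compound 1 `Cc1cc(/C=C/C#N)cc(C)c1Oc1cc(Nc2ccc(C#N)cc2)c(N)cc1[N+](=O)[O-]`: 0.29 ug/mL
compound 2 `Cc1cc(CCC#N)cc(C)c1Oc1cc(Nc2ccc(C#N)cc2)c(N)cc1CO`: 18.8 ug/mL
compound 3 `Cc1cc(CCC#N)cc(C)c1Oc1cc(Nc2ccc(C#N)cc2)c(N)cc1C(F)(F)F`: 0.24 ug/mL

Compound 1 lies within the usual scatter of compound 3 and well under compound 2. Compound 4 `CNC(=O)c1cc(N)c(Nc2ccc(C#N)cc2)cc1Oc1c(C)cc(/C=C/C#N)cc1C` carries methylcarbamoyl in place of nitro on an aromatic carbon. Among the measured compounds shown here, only one measured step bears on this, and loosely: trifluoromethyl in place of hydroxymethyl gave a 78-fold lower number from compound 2 to compound 3 (1.89 log units; beyond the scatter), a large step involving neither group of the new change. Read in reverse, with methylcarbamoyl taken as nearer hydroxymethyl and nitro as nearer trifluoromethyl, it suggests an upward move of smaller size. In this assay the expected step is a 5.2-fold higher number from compound 1 to compound 4 (0.71 log units; beyond the scatter). For compound 4 the estimated value is 1.5 ug/mL, with an expected range from 0.4 ug/mL to 6 ug/mL.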

Compound 4, solubility: 1.32 ug/mL
For compound 4 the middle estimate is 1.1-fold (0.06 log units) above the measured one, and the stated range covers the measured number.
By their numbers in this assay, from the lowest: compounds 3 and 1 (each within the scatter of the next); then compound 4; then compound 2.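

At this aromatic carbon, methylcarbamoyl in place of nitro gives a 4.6-fold higher number from compound 1 to compound 4 (0.66 log units; beyond the scatter) in this assay. Among the compounds shown here, the position therefore responds to a change of group on this core as well, whereas the only earlier step here, between hydroxymethyl and trifluoromethyl, was read on a core with a different chain. Nothing available explains the rise, although the amide hydrogen is a donor that nitro lacks.

On these data alone, whether a primary carboxamide or a carboxylic acid at this position would go further remains open. So does whether the step would carry over to the core of compound 2.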